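The source may report more compounds than this note shows. Statements on the series, on what has been measured and on what is new or still open speak of the compounds shown alone.

Measured so far in a functional assay (uterus) for inhibition, with Rattus norvegicus as the target; a lower number here means that less compound is needed, a higher number that more compound is needed for the effect:
- compound 1 `ClCc1cn2ccncc2n1`: 1.4 nM
- compound 2 `CCOC(=O)Cc1cn2cc(Br)nc(Br)c2n1`: 0.096 nM
- compound 3 `CCOC(=O)c1cn2c(Br)cncc2n1`: 1.02 nM

Compound 1 and compound 3 lie within the scatter of each other. Compound 2 gives a lower number than compound 1, and that gap lies beyond the scatter, so less of compound 2 is needed for the effect.

The next compound is compound 4 `N#Cc1cn2ccncc2n1`, which has cyano in place of chloromethyl on an aromatic carbon of the five-membered aromatic ring: cyano in place of chloromethyl on an aromatic carbon. Within the data shown here, no pair of measured compounds differs in only one place, so the size of this change in this assay has no direct precedent. Compound 1 differs from compound 2 in several places, so the value of compound 2 at 0.096 nM says little about this single change. The closest guide is that compound 1 at 1.4 nM and compound 3 at 1.02 nM carry different groups on this same carbon and still lie within the scatter of each other, although the core of compound 3 also carries a bromo group.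

No step beyond the scatter is therefore expected, and neither direction is favoured. The estimated step is a 1.2-fold lower number from compound 1 to compound 4 (0.07 log units; within the scatter). For compound 4 the expected value is 1.2 nM, with an estimated range from 0.25 nM to 6 nM.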

Compound 4, concentration for half-maximal effect: 2.38 nM
Compound 4: the middle estimate sits 2.0-fold (0.30 log units) below what was measured; low and high end bracket the measured number.
By their numbers in this assay, from the lowest: compound 2; then compounds 3, 1 and 4 (each within the scatter of the next, the first and the last beyond it).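

In this assay, the series now has its first comparison of compounds that differ in one place: a 1.7-fold higher number from compound 1 to compound 4 (0.23 log units; within the scatter), so cyano in place of chloromethyl on this aromatic carbon of the five-membered aromatic ring gives no step beyond the scatter. The exchange brings in a triple bond and a hydrogen-bond acceptor, and in this pair neither comes with a change that can be read in this assay's numbers. Nothing measured here bears on the reason for this result.

The compounds shown leave open whether a group of another kind on this carbon, such as an amine, a carboxylic acid or a longer alkyl chain, would give a step beyond the scatter from compound 1. What a bromo group on the shared core does on its own also stays open, as does which of the several differences between compound 1 and compound 2 accounts for the gap between them.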